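The source may report more compounds than this note shows. Statements on the series, on what has been measured and on what is new or still open speak of the compounds shown alone.

Measured compounds, in a functional assay on HCT-116 cells (Homo sapiens) for inhibition, read by MTT assay, with a stated time of 24 h, tested at 5 uM; on this read-out lower numbers stand for less inhibition of growth and higher numbers for more inhibition of growth at the one concentration tested:
compound 1 `O=c1c(-c2nnc(-c3ccc(F)cc3)o2)c[nH]c2ncc(-c3cccnc3)cc12` gives 11.1%
compound 2 `N#Cc1ccc(-c2cnc3[nH]cc(-c4nnc(-c5ccc(F)cc5)o4)c(=O)c3c2)cc1` gives 12.6%
compound 3 `Cc1ccc(-c2nnc(-c3c[nH]c4ncc(-c5ccc(S(C)(=O)=O)cc5)cc4c3=O)o2)cc1` gives 20.4%

Compound 3 holds the highest of the three numbers, but the gap to compound 2 and the gap to compound 1 both lie within the scatter, so the three compounds cannot be set apart on these values.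

The next compound is compound 4 `CS(=O)(=O)c1ccc(-c2cnc3[nH]cc(-c4nnc(-c5ccccn5)o4)c(=O)c3c2)cc1`. It differs from compound 3 in one place: pyridin-2-yl in place of 4-methylphenyl on an aromatic carbon.

For the measured compounds named here, only one measured step is available, a number 1.5 percentage points higher from compound 1 to compound 2 (within the scatter). That step alters the group on the other end of the shared core, not the aryl on the five-membered aromatic ring with 2 nitrogen and 1 oxygen, and it stays within the scatter. Going by the values given here, no measured pair varies the group that changes here, so nothing speaks for a shift in either direction, and the expectation for this assay is a step of no more than the scatter, with the direction left open.

Compound 4 is therefore expected to give about 18% in this assay, with a range of 7% to 30%, an expected step of a number 2.4 percentage points lower from compound 3 to compound 4 (within the scatter).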

Compound 4, percent growth inhibition at one concentration: 11.3%
Compound 4: the middle estimate sits 6.7 percentage points above what was measured; the range from low to high includes it.
By their numbers in this assay, from the lowest: compounds 1, 4, 2 and 3 (each within the scatter of the next).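

In this assay, for the compounds shown here, the first measured exchange on the aromatic carbon of the five-membered aromatic ring with 2 nitrogen and 1 oxygen reads as a number 9.1 percentage points lower from compound 3 to compound 4 (within the scatter), so pyridin-2-yl in place of 4-methylphenyl cannot be told apart from no effect at this position. Going by these compounds alone, until now the only measured step lay at the other end of the shared core, so this is the first reading at this position, and a ring with 1 hetero atom and 1 hydrogen-bond acceptor can stand in place of a carbon-only ring with no hydrogen-bond acceptor without a step beyond the scatter. No measured property of either group is at hand to bear on this reading.

One exchange between two six-membered aromatic rings, read at a single concentration, does not settle whether this position matters for growth inhibition at all. Still open, going by these compounds, is whether a carboxylic acid, an amine or a longer alkyl chain on this carbon would give a step beyond the scatter, and whether pyridin-2-yl would read the same with a different group at the other end of the shared core.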